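Reversed amide series: shifting the amide one bond inward

The source may report more compounds than this note shows. Statements on the series, on what has been measured and on what is new or still open speak of the compounds shown alone.

Measured compounds: compound 1 `COc1ccc2cccc(C3CNC(=O)C3)c2c1` gives 1580 nM; compound 2 `CCCNC(=O)NCCCc1cccc2ccc(OC)cc12` gives 251 nM; compound 3 `COc1ccc2cccc(CCCC(N)=O)c2c1` gives 20 nM in an assay (Ovis aries) for binding affinity to melatonin receptor type 1A (Homo sapiens); on this read-out higher numbers stand for weaker inhibition and lower numbers for stronger inhibition.

Compound 3 holds the lowest number of the three, so in this assay it is the strongest binder shown. Its nearest neighbour is compound 2, separated by a 13-fold lower number from compound 2 to compound 3 (1.10 log units; beyond the scatter); the widest gap is to compound 1, a 79-fold lower number from compound 1 to compound 3 (1.90 log units; beyond the scatter). Both steps lie beyond the scatter.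

Compound 4 `CNC(=O)CCc1cccc2ccc(OC)cc12` is not yet measured. Its difference from compound 3 is methylcarbamoyl in place of carbamoylmethyl on a saturated chain carbon, two bonds along the chain from an aromatic carbon. Among the measured compounds shown here, no measured step repeats this change. The step from compound 2 to compound 3 shows that what sits at the end of the chain moves the number a great deal; the step from compound 1 to compound 3 shows that the shape of the chain itself does too. Since compound 4 keeps an amide at the chain end but moves it one bond inward and adds a methyl on the nitrogen, a step of moderate size is expected, most likely toward a higher number, as a 2.5-fold higher number from compound 3 to compound 4 (0.40 log units; beyond the scatter). Compound 4 is therefore estimated at 50 nM, with a range from 10 nM to 250 nM.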

Compound 4, half-maximal inhibitory concentration: 12.6 nM
Estimate against measurement, compound 4: 4.0-fold (0.60 log units) above; the range from low to high includes it.
By their numbers in this assay, from the lowest: compounds 4 and 3 (each within the scatter of the next); then compound 2; then compound 1.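

In this assay, the same atoms joined differently, with 2-(methylcarbamoyl)ethyl in place of 3-carbamoylpropyl, give a 1.6-fold lower number from compound 3 to compound 4 (0.20 log units; within the scatter), so at this position the amide can be placed either way along the chain without a step that can be told from the scatter. Set against the ring-bearing 5-oxopyrrolidin-3-yl group, this second ring-free chain gives a 130-fold lower number from compound 1 to compound 4 (2.10 log units; beyond the scatter) and so repeats the large gap already seen with 3-carbamoylpropyl, although two chains are a narrow basis for a pattern. Nothing among the data bears on why the two amide arrangements read alike.

The shift of the amide and the methyl on its nitrogen come as one change here, so their separate contributions remain unresolved. As far as these compounds go, how far this tolerance extends is also open, as a longer ethylcarbamoyl group, a carboxylic acid or an amine at the chain end could read quite differently.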